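Methoxy for Bromo: What to Expect of Compound 4

The source may report more compounds than this note shows. Statements on the series, on what has been measured and on what is new or still open speak of the compounds shown alone.

Compound 1 `COc1ccc(-c2nn(-c3ccccc3)cc2C(=O)Nc2ccc(Br)cc2)cc1` serves as the starting point. In a functional assay on MCF7 cells (Homo sapiens) for cytotoxicity, read by MTT assay, with a stated time of 48 h (a higher number here means a weaker inhibitor, a lower number a stronger inhibitor), compound 1 gives 8210 nM. Compound 2 `COc1ccc(NC(=O)c2cn(-c3ccccc3)nc2-c2ccc(OC)cc2)cc1` differs from it only by methoxy in place of bromo on an aromatic carbon; in this assay compound 2 gives 1770 nM, which amounts to a 4.6-fold lower number from compound 1 to compound 2 (0.67 log units; beyond the scatter). Compound 3 `O=C(Nc1ccc(Br)cc1)c1cn(-c2ccccc2)nc1-c1ccc(Cl)cc1` rests on a different core, set apart from compound 1 by chloro in place of methoxy on an aromatic carbon; in this assay compound 3 gives 5310 nM, a step of a 1.5-fold lower number from compound 1 to compound 3 (0.19 log units; within the scatter). Compound 4 `COc1ccc(NC(=O)c2cn(-c3ccccc3)nc2-c2ccc(Cl)cc2)cc1` has not yet been measured. It differs from compound 3 by methoxy in place of bromo on an aromatic carbon, the same change that separates compound 2 from compound 1, at the same place. Since that change gave a 4.6-fold lower number from compound 1 to compound 2 (0.67 log units; beyond the scatter), a comparable shift is expected here, and compound 4 is estimated to move by a 3.8-fold lower number from compound 3 to compound 4 (0.58 log units; beyond the scatter) in this assay. The estimate for compound 4 in this assay is 1400 nM, expected to fall between 600 nM and 3500 nM.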

Compound 4, half-maximal inhibitory concentration: 1550 nM
The estimate for compound 4 lay 1.1-fold (0.04 log units) below the measured number, within the range that was stated.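

In this assay methoxy in place of bromo again gave a 3.4-fold lower number from compound 3 to compound 4 (0.53 log units; beyond the scatter), and the step carried over to the second core at a similar size: the same change on two cores in this assay, a 4.6-fold lower number (0.67 log units; beyond the scatter) from compound 1 to compound 2 and a 3.4-fold lower number (0.53 log units; beyond the scatter) from compound 3 to compound 4, 1.4-fold (0.13 log units) apart, within the scatter of two such steps. Chloro in place of methoxy gave a 1.1-fold lower number from compound 2 to compound 4 (0.06 log units; within the scatter), so this change also matched on both cores, with no readable difference on either: the same change on two cores in this assay, a 1.5-fold lower number (0.19 log units; within the scatter) from compound 1 to compound 3 and a 1.1-fold lower number (0.06 log units; within the scatter) from compound 2 to compound 4, 1.4-fold (0.13 log units) apart, within the scatter of two such steps. This shows that the two changes added up consistently across these four compounds, but two pairs of closely related cores do not show that either change would carry to any other core, and they do not explain the result.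

The compounds shown leave open whether an amine, a carboxylic acid or a longer chain in the same place would follow the methoxy step. They also leave open how these four compounds would behave outside this assay.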